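This account rests on a few compounds, and the source may have more. Where it says the series, first, only, none or still open, it means among the compounds named here.

Of the compounds shown here, three sharing one core have been tested in a functional assay on MGC-803 cells (Homo sapiens) for cytotoxicity, read by MTT assay, with a stated time of 72 h; on this read-out lower numbers stand for stronger inhibition and higher numbers for weaker inhibition. Compound 1 `O=C1C(=Cc2ccc(Cl)cc2)C(=O)N(c2ccc(Cl)cc2)N1c1ccc(Cl)cc1` gives 32600 nM, the highest of the three numbers. Compound 2 `COc1cccc(C=C2C(=O)N(c3ccc(Cl)cc3)N(c3ccc(Cl)cc3)C2=O)c1O` gives 24300 nM, and compound 3 `O=C1C(=Cc2cccc(Cl)c2)C(=O)N(c2ccc(Cl)cc2)N1c1ccc(Cl)cc1` gives 14400 nM. Exchanging the group on the double-bonded chain carbon has shifted the numbers only a little: a 1.3-fold lower number from compound 1 to compound 2 (0.13 log units; within the scatter), and a 2.3-fold lower number from compound 1 to compound 3 (0.35 log units; beyond the scatter). Compound 4 `COc1ccccc1C=C1C(=O)N(c2ccc(Cl)cc2)N(c2ccc(Cl)cc2)C1=O` carries another such exchange, (2-methoxyphenyl in place of 4-chlorophenyl on a double-bonded chain carbon bound to a double-bonded ring carbon). Since both exchanges already seen at this place left compound 1 nearly where it started, compound 4 is expected to land close to compound 1, with at most a small move downward, so that a 1.3-fold lower number from compound 1 to compound 4 (0.10 log units; within the scatter) is the estimated step. Compound 4 is therefore estimated at 26000 nM, between 11000 nM and 60000 nM.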

Compound 4, half-maximal inhibitory concentration: 28600 nM
Compound 4: the middle estimate sits 1.1-fold (0.04 log units) below what was measured; the measured number falls inside the stated range.
By their numbers in this assay, from the lowest: compounds 3, 2, 4 and 1 (each within the scatter of the next, the first and the last beyond it).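

Replacing 4-chlorophenyl with 2-methoxyphenyl, which has no chlorine and one hydrogen-bond acceptor, gives a 1.1-fold lower number from compound 1 to compound 4 (0.06 log units; within the scatter), so this exchange at the double-bonded chain carbon leaves the number essentially unchanged. Compound 2 also stays close, with a 1.2-fold higher number from compound 2 to compound 4 (0.07 log units; within the scatter), so the added hydroxyl of its 2-hydroxy-3-methoxyphenyl group brings no measurable gain here. Compound 3 likewise gives a 2.0-fold higher number from compound 3 to compound 4 (0.30 log units; within the scatter), at the edge of the usual variation. Still open, going by these compounds, is whether an amine or a carboxylic acid at this place would move the number further. No evidence is available on what lies behind these small steps.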